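This account rests on a few compounds, and the source may have more. Where it says the series, first, only, none or still open, it means among the compounds named here.

Measured compounds:
- compound 1 `O=[N+]([O-])c1ccccc1-c1nc(NCc2ccc(-c3cccnc3)cc2)c2ccccc2n1` — 7800 nM in an assay on a protein complex for inhibition of ubiquitin carboxyl-terminal hydrolase 1/WD repeat-containing protein 48 (Homo sapiens), read by fluorescence; a lower number here means a stronger inhibitor, a higher number a weaker inhibitor
- compound 2 `CCc1ccccc1-c1nc(NCc2ccc(-c3cccnc3)cc2)c2ccccc2n1` — 780 nM
- compound 3 `FC(F)c1ccccc1-c1nc(NCc2ccc(-c3cccnc3)cc2)c2ccccc2n1` — 1400 nM

Compound 3 holds the second highest of the three numbers in this assay. Its nearest neighbour is compound 2: the step of a 1.8-fold higher number from compound 2 to compound 3 (0.25 log units; within the scatter) stays within the scatter. Its furthest is compound 1: the step of a 5.6-fold lower number from compound 1 to compound 3 (0.75 log units; beyond the scatter) lies beyond the scatter, as does a 10-fold lower number from compound 1 to compound 2 (1.00 log units; beyond the scatter).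

Compound 4 `Brc1ccccc1-c1nc(NCc2ccc(-c3cccnc3)cc2)c2ccccc2n1` is the next member of the series. It differs from compound 3 by bromo in place of difluoromethyl on an aromatic carbon.

All three measured steps are swaps at this same aromatic carbon, and they bear directly on the new one. Nitro gives the weakest number of the series; ethyl and difluoromethyl give numbers within the scatter of each other. A second non-nitro group at this position is therefore expected to land near compound 2 and compound 3 rather than near compound 1, with a step of a 1.4-fold lower number from compound 3 to compound 4 (0.15 log units; within the scatter) that is not expected to exceed the scatter. Compound 4 is estimated at 1000 nM, within a range from 400 nM to 3000 nM.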

Compound 4, half-maximal inhibitory concentration: 1600 nM
Estimate against measurement, compound 4: 1.6-fold (0.20 log units) below; the measured number falls inside the stated range.
By their numbers in this assay, from the lowest: compounds 2, 3 and 4 (each within the scatter of the next, the first and the last beyond it); then compound 1.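

In this assay, bromo, with 1 heavy atom, in place of difluoromethyl, with 3 heavy atoms, gives a 1.1-fold higher number from compound 3 to compound 4 (0.06 log units; within the scatter), so at this aromatic carbon the difference in heavy-atom count between these two groups does not move the number beyond the scatter. Bromo in place of ethyl gives a 2.1-fold higher number from compound 2 to compound 4 (0.31 log units; beyond the scatter), the only step among the non-nitro groups that lies beyond the scatter, and it is modest, while bromo in place of nitro gives a 4.9-fold lower number from compound 1 to compound 4 (0.69 log units; beyond the scatter), which leaves nitro apart from all three other groups as the weakest of the series. Nothing available here accounts for these differences.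

Still open, as far as these compounds go, is whether an amine, a carboxylic acid or a longer alkyl chain at this carbon would stay with ethyl, difluoromethyl and bromo or move towards nitro. The compounds shown also leave open whether the gap between ethyl and bromo would persist with a change elsewhere on the shared core.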